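Amide substituent variation, compound 3 to compound 4

A few compounds are considered here, and "the series" means these few. Any claim that something is new, unique, unknown or untested is made for them only; others in the source may bear on it.

Compound 3 `CCCCCCNC(=O)CC1CCc2cc(OC)c(OC)cc21` gives 44.6% in a functional assay on the whole organism (strain Wistar) for inhibition, with Rattus norvegicus as the target, read by paw edema, with stated times of 60 min and 3 h, at a dose of 100 mg/kg by the oral route (on this read-out lower numbers stand for less inhibition and higher numbers for more inhibition at the one dose given (going by the name of the read-out)), the highest of the three numbers measured. Compound 1 `CCN(CC)C(=O)CC1CCc2cc(OC)c(OC)cc21` gives 37.7% in this assay, and compound 2 `CCCCNC(=O)CC1CCc2cc(OC)c(OC)cc21` gives 27.5%. The gap between compound 3 and compound 1 is within the scatter, whereas a number 17.1 percentage points higher from compound 2 to compound 3 (beyond the scatter) and a number 10.2 percentage points lower from compound 1 to compound 2 (beyond the scatter) both lie beyond it. Compound 4 `COc1cc2c(cc1OC)C(CC(=O)NCCO)CC2` differs from compound 3 by hydroxy in place of butyl on a saturated chain carbon, two bonds along the chain from an amide-type nitrogen. For the measured compounds named here, the step of a number 17.1 percentage points higher from compound 2 to compound 3 (beyond the scatter) shows a longer chain at the amide-type nitrogen going with a higher number, so the much shorter chain of compound 4 points downward; no measured step covers a hydroxy group, so its effect is unknown. For compound 4 the expected step is a number 19.6 percentage points lower from compound 3 to compound 4 (beyond the scatter). Compound 4 is therefore estimated at 25%, with a range of 10% to 40%.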

Compound 4, a percentage reported as inhibition, in the whole organism at one dose (the size of the read-out at that dose, not a potency): 12.3%
For compound 4 the middle estimate is 12.7 percentage points above the measured one; the measured number falls inside the stated range.
By their numbers in this assay, from the lowest: compound 4; then compound 2; then compounds 1 and 3 (each within the scatter of the next).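

For the compounds shown here, the (2-hydroxyethyl)amino group gives the lowest number so far in this assay, with a number 32.3 percentage points lower from compound 3 to compound 4 (beyond the scatter) and a number 15.2 percentage points lower from compound 2 to compound 4 (beyond the scatter) and a number 25.4 percentage points lower from compound 1 to compound 4 (beyond the scatter) on the same read-out. Hydroxy at this chain position therefore goes with a lower number against butylamino as well as hexylamino and diethylamino. Nothing measured here accounts for this drop.

Going by these compounds, whether the hydroxy or the shorter chain carries the drop stays open. An ethylamino or a 6-hydroxyhexylamino group on the same carbonyl would separate the two.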